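A few compounds are considered here, and "the series" means these few. Any claim that something is new, unique, unknown or untested is made for them only; others in the source may bear on it.

In a functional assay on L1210 cells (Mus musculus) for inhibition (a lower number here means a stronger inhibitor, a higher number a weaker inhibitor), compound 3 `C#CCN(Cc1ccc2nc(C)nc(O)c2c1)c1ccc(Cl)cc1` gives only > 4000 nM, which is a limit and not a number. Two relatives carry other groups on the same amine nitrogen and do give numbers: compound 1 `C#CCN(Cc1ccc2nc(C)nc(O)c2c1)c1cccc(CC)c1` gives 5000 nM, and compound 2 `C#CCN(Cc1ccc2nc(C)nc(O)c2c1)c1cccc(CO)c1` gives 48000 nM.

The next compound, compound 4 `C#CCN(Cc1ccc2nc(C)nc(O)c2c1)c1ccc(S(N)(=O)=O)cc1`, changes compound 3 in one place: sulfamoyl in place of chloro on an aromatic carbon. This puts sulfamoyl in place of chloro on an aromatic carbon, para to a large group.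

Among the compounds with values here, no measured step makes this exchange. Within the data shown here, the only readable step is a 9.6-fold higher number from compound 1 to compound 2 (0.98 log units; beyond the scatter), in which hydroxy takes the place of methyl on a saturated chain carbon bound to an aromatic carbon. The other two, a step that the limit leaves unreadable from compound 1 to compound 3 and a step that the limit leaves unreadable from compound 2 to compound 3, give no size.

That leaves thin support for a forecast. Among the measured compounds shown here, with the step to compound 2 at 48000 nM as the only guide, a modest move towards a higher number is expected in this assay. The starting point, compound 3 at > 4000 nM, is only a limit. The estimated change is a step that the limit leaves unreadable from compound 3 to compound 4. For compound 4 the estimate is 15000 nM, with an expected range from 4000 nM to 60000 nM.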

Compound 4, half-maximal inhibitory concentration: 20000 nM
For compound 4 the middle estimate is 1.3-fold (0.12 log units) below the measured one; low and high end bracket the measured number.
By their numbers in this assay, from the lowest: compound 1; then compound 4; then compound 2.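

The step from compound 3 to compound 4 cannot be read, because compound 3 has only a limit and not a number in this assay: the limit of > 4000 nM in this assay, at which 1 of the 4 values shown sits.

The compounds shown leave open how large the effect of sulfamoyl in place of chloro is on this aromatic carbon, and in which direction it moves the number.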